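Swapping the Halogenated Aryl Group: Compound 3 to Compound 4

The source may report more compounds than this note shows. Statements on the series, on what has been measured and on what is new or still open speak of the compounds shown alone.

Among the three compounds measured in a functional assay on MCF7 cells (Homo sapiens) for inhibition (a higher number here means a weaker inhibitor, a lower number a stronger inhibitor), compound 3 `CC/C(=C(/c1ccc(/C=C/C(=O)O)cc1)c1cc2ccccc2[nH]1)c1ccc(C(F)(F)F)cc1Cl` gives 27 nM, the lowest number of the set. Compound 1 `CC/C(=C(/c1ccc(/C=C/C(=O)O)cc1)c1cc2ccccc2[nH]1)c1ccccc1` gives 108 nM and compound 2 `CC/C(=C(/c1ccc(/C=C/C(=O)O)cc1)c1cc2ccccc2[nH]1)c1ccc(C#N)cc1` gives 278 nM. The steps toward compound 3 read a 4.0-fold lower number from compound 1 to compound 3 (0.60 log units; beyond the scatter) and a 10-fold lower number from compound 2 to compound 3 (1.01 log units; beyond the scatter), while a 2.6-fold higher number from compound 1 to compound 2 (0.41 log units; beyond the scatter). Compound 4 `CC/C(=C(/c1ccc(/C=C/C(=O)O)cc1)c1cc2ccccc2[nH]1)c1c(C)cccc1Cl` differs from compound 3 by 2-chloro-6-methylphenyl in place of 2-chloro-4-(trifluoromethyl)phenyl on a double-bonded chain carbon bound to a double-bonded chain carbon and a saturated chain carbon. Going by the values given here, no measured step covers this exact change: the chloro stays, the trifluoromethyl leaves and a methyl enters. Among the compounds with values here, the nearest guide is a 4.0-fold lower number from compound 1 to compound 3 (0.60 log units; beyond the scatter), a gain that came with both the chloro and the trifluoromethyl together; with only one of those two groups remaining, part of that gain is expected to be lost, though the retained chloro argues against a full return to the number of compound 1. Compound 4 is therefore expected to show a modest rise, a 2.2-fold higher number from compound 3 to compound 4 (0.35 log units; beyond the scatter). The estimate for compound 4 in this assay is 60 nM, with a range of 20 nM to 180 nM.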

Compound 4, half-maximal inhibitory concentration: 30 nM
Beside the measured number, compound 4's estimate is 2.0-fold (0.30 log units) above it; the range from low to high includes it.
By their numbers in this assay, from the lowest: compounds 3 and 4 (each within the scatter of the next); then compound 1; then compound 2.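

In this assay, 2-chloro-6-methylphenyl in place of 2-chloro-4-(trifluoromethyl)phenyl at this double-bonded chain carbon gives a 1.1-fold higher number from compound 3 to compound 4 (0.05 log units; within the scatter), so the number of compound 3 does not depend on the trifluoromethyl group being present. The new aryl group also gives a 3.6-fold lower number from compound 1 to compound 4 (0.56 log units; beyond the scatter) and a 9.3-fold lower number from compound 2 to compound 4 (0.97 log units; beyond the scatter), which shows that both chloro-bearing compounds, not just compound 3, have lower numbers than the unsubstituted phenyl and 4-cyanophenyl compounds. Nothing available explains why these two different aryl groups give matching numbers.

The compounds shown leave open how a phenyl carrying only the chloro or only a methyl would compare, so the contribution of each group cannot be separated. Also open, from the compounds shown here alone, is whether a bromine or a methoxy group could stand in for the chloro at this place.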